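This account rests on a few compounds, and the source may have more. Where it says the series, first, only, none or still open, it means among the compounds named here.

Working notes on the series, on a physicochemical assay for solubility, measured as kinetic solubility; on this read-out higher numbers stand for higher solubility and lower numbers for lower solubility. Compound 1 `CCC/N=C1\S/C(=C\c2ccc(O)c(Cl)c2)C(=O)N1C1CCS(=O)(=O)CC1` gives 75000 nM and compound 2 `CCC/N=C1\S/C(=C\c2ccc(O)cn2)C(=O)N1c1ccccc1C` gives 110000 nM, so the two values lie within the usual scatter of each other. Within the data shown here, compound 2 therefore stands level with compound 1 on the numbers so far. Among the measured compounds shown here, the two compounds differ in more than one place, and no single-place step between measured compounds is available as a guide.

The next compound, compound 3 `CCC/N=C1\S/C(=C\c2ccc(O)cc2)C(=O)N1c1ccccc1C`, has 4-hydroxyphenyl in place of 5-hydroxypyridin-2-yl on a double-bonded chain carbon bound to a double-bonded ring carbon. The estimated step of a 1.6-fold lower number from compound 2 to compound 3 (0.20 log units; within the scatter) is expected to be small and downward, not clearly beyond the scatter. For the measured compounds named here, this expectation is weakly founded, since the data hold no direct precedent for the change. For compound 3 the expected value in this assay is 70000 nM, with an estimated range of 30000 nM to 130000 nM.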

Compound 3, solubility: 79000 nM
For compound 3 the middle estimate is 1.1-fold (0.05 log units) below the measured one; measured number inside the range.
By their numbers in this assay, from the lowest: compounds 1, 3 and 2 (each within the scatter of the next).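

Among these compounds, with 4-hydroxyphenyl in place of 5-hydroxypyridin-2-yl on a double-bonded chain carbon bound to a double-bonded ring carbon, this assay gives a 1.4-fold lower number from compound 2 to compound 3 (0.14 log units; within the scatter), the first single-place step. At this place, then, exchanging the one ring with a hetero atom for the ring of carbon only leaves the two compounds level within the scatter, and the read-out stays in the same range as that of compound 1. Nothing at hand bears on the origin of this step.

Still open, as far as these compounds go, is what a ring bearing a carboxylic acid or a dimethylamino group would give at this place in this assay. Also open, from the compounds shown here alone, is whether the same exchange would give a step of similar size with the remaining parts of compound 1.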